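A Chloro Swap on the Benzyl Arm, Second Time Around

The source may report more compounds than this note shows. Statements on the series, on what has been measured and on what is new or still open speak of the compounds shown alone.

Compound 3 `CC1=C(C(=O)Nc2ccc([N+](=O)[O-])cc2)C(c2cccc([N+](=O)[O-])c2)N=C(SCc2ccccc2)N1` gives 21% in a functional assay on the whole organism (artery, strain albino) with Rattus norvegicus as the target, with a stated time of 240 min, at a dose of 10 mg/kg by the oral route; a lower number here means less inhibition, a higher number more inhibition at the dose given (going by the name of the read-out). Compound 1 `CC1=C(C(=O)Nc2ccc([N+](=O)[O-])cc2)C(c2ccc(Br)cc2)N=C(SCc2ccccc2)N1` gives 27.7%, and the step of a number 6.7 percentage points lower from compound 1 to compound 3 (within the scatter) keeps these two within the usual scatter. Compound 2 `CC1=C(C(=O)Nc2ccc([N+](=O)[O-])cc2)C(c2ccc(Br)cc2)N=C(SCc2ccccc2Cl)N1` gives 15.4%, which also lies within the scatter of compound 3. Compound 3 thus sits among three numbers without being separated from either neighbour by more than the scatter, although compound 1 and compound 2 are separated from each other by more than it.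

Compound 4 `CC1=C(C(=O)Nc2ccc([N+](=O)[O-])cc2)C(c2cccc([N+](=O)[O-])c2)N=C(SCc2ccccc2Cl)N1` differs from compound 3 by chloro in place of hydrogen on an aromatic carbon. The same change has been measured once before, in the step of a number 12.3 percentage points lower from compound 1 to compound 2 (beyond the scatter), which ran beyond the scatter. Within the data shown here, that is the only measured step bearing on the new one, so a fall of similar size is the natural expectation, though a single precedent carries limited weight. The expected step is a number 12 percentage points lower from compound 3 to compound 4 (beyond the scatter). Compound 4 is estimated at 9% in this assay, with a likely range from 0% to 19%.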

Compound 4, a percentage reported as inhibition, in the whole organism at one dose (the size of the read-out at that dose, not a potency): 12.8%
Estimate against measurement, compound 4: 3.8 percentage points below, and the stated range covers the measured number.
By their numbers in this assay, from the lowest: compounds 4, 2, 3 and 1 (each within the scatter of the next, the first and the last beyond it).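

In this assay, chloro in place of hydrogen on the benzyl arm gives a number 8.2 percentage points lower from compound 3 to compound 4 (within the scatter), so on this core the change alone cannot be told apart from the scatter, unlike its first measured instance. Set side by side, the two chloro steps agree, which means a single size could describe the change on both cores: the same change on two cores in this assay, a number 12.3 percentage points lower (beyond the scatter) from compound 1 to compound 2 and a number 8.2 percentage points lower (within the scatter) from compound 3 to compound 4, 4.1 percentage points apart, within the scatter of two such steps The swap on the saturated ring carbon, 3-nitrophenyl in place of 4-bromophenyl, now gives a number 2.6 percentage points lower from compound 2 to compound 4 (within the scatter), and it also reads alike with and without the chloro: the same change on two cores in this assay, a number 6.7 percentage points lower (within the scatter) from compound 1 to compound 3 and a number 2.6 percentage points lower (within the scatter) from compound 2 to compound 4, 4.1 percentage points apart, within the scatter of two such steps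

The compounds shown carry only hydrogen or chloro at this place on the benzyl ring, so it remains open how a methoxy group or an amine would read there. Each number also comes from a single dose, so none of them gives a potency.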